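Hydrazide to methylpiperazine amide in the thiophene urea series

This account rests on a few compounds, and the source may have more. Where it says the series, first, only, none or still open, it means among the compounds named here.

Compound 1 `NNC(=O)c1c(NC(=O)NS(=O)(=O)c2ccccc2)sc2c1CCCCC2` gives 15800 nM in a functional assay on cells (Cancer cell lines, Homo sapiens) for inhibition, with a stated time of 48 h; a lower number here means a stronger inhibitor of growth, a higher number a weaker inhibitor of growth. Compound 2 `O=C(Nc1sc2c(c1C(=O)NNc1ccccc1)CCCCC2)NS(=O)(=O)c1ccccc1` in this assay reaches only the limit, > 100000 nM. The step of an at least 6.3-fold higher number from compound 1 to compound 2 (0.80 log units; beyond the scatter) therefore shows loss of activity on adding the phenyl, with compound 2 sitting at the limit of > 100000 nM in this assay, at which 1 of the 2 values shown sits. For the measured compounds named here, compound 3 `CN1CCN(C(=O)c2c(NC(=O)NS(=O)(=O)c3ccccc3)sc3c2CCCCC3)CC1` carries 4-methylpiperazin-1-yl in place of anilinoamino on a carbonyl carbon; this removes the phenyl that weakened compound 2 and also the amide hydrogen donors of compound 1, so no measured step maps onto it directly. A recovery toward the level of compound 1 is expected, an at least 3.3-fold lower number from compound 2 to compound 3 (0.52 log units; beyond the scatter), though uncertain. For compound 3 the estimate is 30000 nM (range 8000 nM to 100000 nM).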

Compound 3, concentration for 50% growth inhibition: 80200 nM
The estimate for compound 3 lay 2.7-fold (0.43 log units) below the measured number; the range from low to high includes it.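

In this assay, exchanging the hydrazide for the methylpiperazine amide gives a 5.1-fold higher number from compound 1 to compound 3 (0.71 log units; beyond the scatter). For the compounds shown here, removing the phenyl therefore does not by itself return activity to the hydrazide level, and the phenyl is not the only change at this position that costs activity. The step of an at least 1.2-fold lower number from compound 2 to compound 3 (0.09 log units; that floor lies within the scatter) starts from a limit of the assay and gives no order between those two compounds.

Still open, as far as these compounds go, is whether a primary amide, a morpholine amide or a carboxylic acid on this carbonyl carbon would keep the level of compound 1 or improve on it.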